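The compounds below may be only part of what the source reports. "The series", "measured", "known", "first", "only" and "open" are said of these compounds alone.

Compounds measured so far:
compound 1, `CCCCNc1nc(N)nc2c1CNCC2`, 7.2 uM
compound 2, `CCCCNc1nc(N)nc2c1CN(Cc1ccc(C(F)(F)F)cc1)CC2`, 0.23 uM
compound 3, `CCCCNc1nc(N)nc2c1CN(Cc1c[nH]c3ccccc13)CC2`, 0.22 uM

In an assay on HEK293 cells for agonist activity at Toll-like receptor 8 (Homo sapiens), read by a luciferase reporter, with a stated time of 6 h (on this read-out lower numbers stand for an effect already at smaller amounts and higher numbers for an effect only at larger amounts of compound), compound 1 stands at the high end of these three numbers: its value is the one reached only at the largest amount, and both compound 2 and compound 3 reach their effect at far smaller amounts, with gaps well beyond the usual scatter. Those two compounds carry a large substituent on the ring nitrogen where compound 1 carries only hydrogen, and the data show no other kind of change on that nitrogen.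

Compound 4, `CCCCNc1nc(N)nc2c1CN(C(=O)C(C)C)CC2`, is not yet measured. It differs from compound 1 in one place: isopropylcarbonyl in place of hydrogen on an amine nitrogen in a ring. The group that enters is much smaller than the groups carried by compound 2 and compound 3 and contains a carbonyl rather than an aromatic ring, so their gains cannot simply be carried over.

The expectation is therefore a modest gain: the step of a 2.9-fold lower number from compound 1 to compound 4 (0.46 log units; beyond the scatter) is estimated to move the number downward, roughly at the edge of the scatter. Compound 4 is expected to give about 2.5 uM in this assay, within a range from 0.4 uM to 12 uM.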

Compound 4, minimum effective concentration: 1.6 uM
Beside the measured number, compound 4's estimate is 1.6-fold (0.19 log units) above it; the measured number falls inside the stated range.
By their numbers in this assay, from the lowest: compounds 3 and 2 (each within the scatter of the next); then compound 4; then compound 1.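

In this assay, putting isopropylcarbonyl in place of hydrogen on the amine nitrogen in the ring gives a 4.5-fold lower number from compound 1 to compound 4 (0.65 log units; beyond the scatter), a modest step but one beyond the scatter. The earlier groups on this nitrogen both contained an aromatic ring, whereas this group has no ring and still lowers the number, so an aromatic ring is not required for a gain here, although compound 4 at 1.6 uM stays above compound 2 at 0.23 uM and compound 3 at 0.22 uM. No measurement available here explains why this change lowers the number.

The compounds shown leave open whether the carbonyl matters or whether any carbon group on this nitrogen would do, a question that a plain isobutyl group, with the same carbon count as isopropylcarbonyl but no carbonyl, could help to settle. As far as these compounds go, it also remains open how the number responds to the size of the group on the carbonyl, for example with a smaller acetyl group, a longer chain or a benzoyl group.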